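Removing a Methoxy Group: Expectations for Compound 3

The source may report more compounds than this note shows. Statements on the series, on what has been measured and on what is new or still open speak of the compounds shown alone.

Measured compounds:
- compound 1 `COc1ccc(/C=C/C(=O)O)cc1OC(=O)c1nc(C)c(C)nc1C`: 128% in a functional assay on EA.hy 926 cells (Homo sapiens) for cytotoxicity, read by MTT assay, with stated times of 24 h and 12 h, tested at 25 uM; on this read-out higher numbers stand for a stronger effect at the one concentration tested and lower numbers for a weaker effect
- compound 2 `CCOC(=O)/C=C/c1ccc(OC)c(OC(=O)c2nc(C)c(C)nc2C)c1`: 60.1% in this assay

Compound 1 stands highest of the two numbers; its nearest neighbour is compound 2, reached by a number 67.9 percentage points lower from compound 1 to compound 2 (beyond the scatter). Compound 3 `Cc1nc(C)c(C(=O)Oc2cccc(/C=C/C(=O)O)c2)nc1C` differs from compound 1 by hydrogen in place of methoxy on an aromatic carbon. For the measured compounds named here, no measured step touches this change, and the only step in hand concerns ethyl in place of hydrogen on an oxygen next to a carbonyl group, so it gives no direct guide. For compound 3 a step no larger than the scatter, perhaps slightly downward, is expected, a number 16 percentage points lower from compound 1 to compound 3 (beyond the scatter). Compound 3 is therefore estimated at 112%, within 75% to 145%.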

Compound 3, a percentage reported as activity, at one concentration (the size of the read-out at that concentration, not a potency): 64.3%
Compound 3: middle estimate off by 47.7 percentage points, on the high side; measured number outside the range, below it.
By their numbers in this assay, from the lowest: compounds 2 and 3 (each within the scatter of the next); then compound 1.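

Replacing the methoxy group with hydrogen, on the aromatic carbon para to a 2-carboxyethenyl group, gives a number 63.7 percentage points lower from compound 1 to compound 3 (beyond the scatter) in this assay. The read-out therefore responds strongly to this carbon as well as to the acid end that the ethyl step changed, so a single small substitution on the ring matters here. Nothing available explains why the number falls. From the compounds shown here alone, whether an ethoxy group, a hydroxyl group or a fluorine atom on this carbon would keep the number of compound 1 remains open. Also open, going by these compounds, is what losing the methoxy group does when the acid is an ethyl ester.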